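This account rests on a few compounds, and the source may have more. Where it says the series, first, only, none or still open, it means among the compounds named here.

The measured compounds and their values in a functional assay on J774 cells (Mus musculus) for cytotoxicity, read by resazurin assay; on this read-out higher numbers stand for weaker inhibition and lower numbers for stronger inhibition:

Compound 1, `Cc1cccc(-c2ccc(C(O)CCCCCO)cc2)c1`, gives > 100000 nM, which is a limit of the assay and not a number.
Compound 2, `OCCCCCC(O)c1ccc(-c2cccc(Cl)c2)cc1`, gives > 100000 nM, likewise a limit of the assay.
Compound 3, `Cc1cc(-c2ccc(F)cc2F)ccc1C(=O)CCCCCO`, gives 4000 nM.

The change from compound 1 to compound 2 is chloro in place of methyl on an aromatic carbon. The step it made, a step that the two limits leave unreadable from compound 1 to compound 2, cannot be read, since both compounds sit at the limit of > 100000 nM in this assay, at which 2 of the 3 values shown sit. Within the data shown here, compound 3 is the only compound of the three with a number rather than a limit. The difference between the core of compound 1 and the core of compound 3 is not broken down here.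

Compound 4, `O=C(CCCCCO)c1ccc(-c2ccc(F)cc2F)cc1Cl`, has not yet been measured in this assay. It differs from compound 3 by chloro in place of methyl on an aromatic carbon. This is the same kind of change as that from compound 1 to compound 2, but the surroundings differ: in compound 2 the chloro sits meta to a large group, whereas in compound 4 it sits ortho to a group of 8 heavy atoms and meta to a group of 8 heavy atoms.

The earlier step, a step that the two limits leave unreadable from compound 1 to compound 2, gives no guidance on size. The expectation therefore rests on compound 3 and its value 4000 nM, with a step of no change at the digits printed from compound 3 to compound 4 (within the scatter) expected for the swap in this assay. Compound 4 is estimated at 4000 nM, most likely between 1300 nM and 12000 nM.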

Compound 4, half-maximal inhibitory concentration: 7000 nM
Compound 4: the middle estimate sits 1.8-fold (0.24 log units) below what was measured; the measured number falls inside the stated range.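

In this assay, chloro in place of methyl on an aromatic carbon of the core of compound 3 makes a 1.8-fold higher number from compound 3 to compound 4 (0.24 log units; within the scatter), so on this core the swap leaves the read-out where repeated measurements would be expected to scatter. The same swap on the core of compound 1 cannot be read, since both of its compounds give a limit of the assay and not a number: the limit of > 100000 nM in this assay, at which 2 of the 4 values shown sit. The series therefore holds a single readable instance of this change, which shows that it is tolerated on the core of compound 3 but does not show that the result carries over to the core of compound 1, or to any other core.

On these data alone, how bromo or trifluoromethyl on that same aromatic carbon would read in this assay stays open, as does the effect of an amine or a carboxylic acid in place of the hydroxyl on the chain, or of a longer chain. No pair shown differs only at the carbonyl, so the part it plays in the gap between the limits of the first two compounds and the numbers of compound 3 and compound 4 also stays open.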